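Trading the aryl group on the ring nitrogen for a methyl

The source may report more compounds than this note shows. Statements on the series, on what has been measured and on what is new or still open speak of the compounds shown alone.

Compound 3 `Cc1ccc(N2CCN(C(=S)SCc3ccc(C(=O)Nc4ccccc4N)cc3)CC2)cc1` sits at the bottom of the three measured values in a functional assay on A-375 cells (Homo sapiens) for antiproliferative activity, read by CCK-8 assay, with a stated time of 72 h, tested at 8 uM (a lower number here means a weaker effect, a higher number a stronger effect of the compound at the concentration tested), where compound 3 gives 26.4%. Compound 1 `Nc1ccccc1NC(=O)c1ccc(CSC(=S)N2CCN(Cc3ccccn3)CC2)cc1` gives 82.4% and compound 2 `Nc1ccccc1NC(=O)c1ccc(CSC(=S)N2CCCc3ccccc32)cc1` gives 81.5%, both far higher. Within the data shown here, the only measured step that changes the same position is a number 56 percentage points lower from compound 1 to compound 3 (beyond the scatter), a large fall that came with putting 4-methylphenyl in place of (pyridin-2-yl)methyl on the amine nitrogen in the ring.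

Compound 4 `CN1CCN(C(=S)SCc2ccc(C(=O)Nc3ccccc3N)cc2)CC1` differs from compound 3 as follows: methyl in place of 4-methylphenyl on an amine nitrogen in a ring. This step bears on the same ring nitrogen as the measured step, which shows that the group at this spot can move the read-out by a very large amount. Methyl is small and unlike either group measured there, so its effect is open. A rise is expected for compound 4 because of the size of a number 56 percentage points lower from compound 1 to compound 3 (beyond the scatter), though with wide uncertainty, giving an estimated step of a number 28.6 percentage points higher from compound 3 to compound 4 (beyond the scatter). In this assay compound 4 is expected to give about 55%, within a range from 25% to 85%.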

Compound 4, a percentage reported as inhibition, at one concentration (the size of the read-out at that concentration, not a potency): 91.6%
Estimate against measurement, compound 4: 36.6 percentage points below; measured number above the stated range.
By their numbers in this assay, from the lowest: compound 3; then compounds 2, 1 and 4 (each within the scatter of the next, the first and the last beyond it).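

Swapping 4-methylphenyl for methyl on the ring nitrogen in this assay gives a number 65.2 percentage points higher from compound 3 to compound 4 (beyond the scatter), so the low read-out of compound 3 goes with that aryl group and not with the ring that carries it. Removing the pyridin-2-yl from the chain carbon gives a number 9.2 percentage points higher from compound 1 to compound 4 (within the scatter), so a ring on the group at this nitrogen does not always go with a low read-out, while 4-methylpiperazin-1-yl in place of 1,2,3,4-tetrahydroquinolin-1-yl on the thiocarbonyl carbon gives a number 10.1 percentage points higher from compound 2 to compound 4 (beyond the scatter), a modest step. Nothing available explains why the 4-methylphenyl group stands apart.

From the compounds shown here alone, whether the low read-out depends on the 4-methyl or on the aromatic ring itself stays open, and an unsubstituted phenyl or a benzyl group on that nitrogen would help separate these. The effect of a longer chain there, such as propyl, is also unknown.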